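The compounds below may be only part of what the source reports. "The series", "measured", "known", "first", "only" and "open" are said of these compounds alone.

In a functional assay on CHO-K1 cells for antagonist activity at C-X-C chemokine receptor type 3 (Homo sapiens), read by FLIPR and calcium flux (on this read-out higher numbers stand for weaker inhibition and lower numbers for stronger inhibition), three compounds built on a shared core have been measured. Compound 1 `CC1CN(c2ccc(C(F)(F)F)cn2)CCN1S(=O)(=O)C[C@]12CC[C@H](CC1=O)C2(C)C` gives 631 nM. Compound 2 `CC1(C)[C@@H]2CC[C@@]1(CS(=O)(=O)N1CCN(c3ccc([N+](=O)[O-])cn3)CC1)C(=O)C2` gives only a limit of the assay, > 31600 nM, and no number. Compound 3 `CC1(C)[C@@H]2CC[C@@]1(CS(=O)(=O)N1CCN(c3ccc(C(F)(F)F)cn3)CC1)C(N)C2` gives 794 nM. Of the two numbers obtained, compound 3 carries the higher one, yet its nearest neighbour is compound 1 and the gap between them is within the usual scatter of repeated measurements, so the two cannot be ranked against each other. The third value is the limit of > 31600 nM in this assay, at which 1 of the 3 values shown sits.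

Compound 4 `CCNC(=O)NC1C[C@H]2CC[C@]1(CS(=O)(=O)N1CCN(c3ccc(C(F)(F)F)cn3)CC1)C2(C)C` is the next compound to be measured in this assay. It differs from compound 3 in a single place: ethylcarbamoyl in place of hydrogen on an amine nitrogen. Going by the values given here, no step between measured compounds covers a change of this kind, so the measured numbers give no direction for it; the only comparison at hand is that compound 1 and compound 3 sit within the scatter of each other. The expected step from compound 3 to compound 4 is therefore small, a 1.3-fold lower number from compound 3 to compound 4 (0.12 log units; within the scatter), in either direction and not clearly beyond the scatter. For compound 4 the estimate in this assay is 600 nM, with a range from 150 nM to 2500 nM.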

Compound 4, half-maximal inhibitory concentration: 794 nM
For compound 4 the middle estimate is 1.3-fold (0.12 log units) below the measured one; the measured number falls inside the stated range.
By their numbers in this assay, from the lowest: compounds 1, 3 and 4 (each within the scatter of the next). At a limit, above all of these: compound 2.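

In this assay, putting ethylcarbamoyl, with its 5 heavy atoms, in place of hydrogen on the amine nitrogen gives no change at the digits printed from compound 3 to compound 4 (within the scatter). Going by these compounds alone, the earlier compounds showed only the plain amino form at this place, so this is the first sign that amino can become (ethylcarbamoyl)amino, a much larger group that brings a hydrogen-bond donor and a hydrogen-bond acceptor, without a visible shift in the measured number. The data at hand offer no explanation for why the number stays put.

On these data alone, it remains open whether other groups on this nitrogen, such as a methyl, an acetyl or a longer chain in place of the ethyl of ethylcarbamoyl, would also stay within the scatter of compound 3 or would move the number clearly up or down. Among the compounds shown, only hydrogen and ethylcarbamoyl can be compared on this nitrogen, so one step cannot tell whether this place accepts nearly any group or just this one.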